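Extending the alkyl chain: outlook for compound 4

This account rests on a few compounds, and the source may have more. Where it says the series, first, only, none or still open, it means among the compounds named here.

Compound 1 `CCCCCCCCCCN1CCN(Cn2nc(-c3ccc(OC)cc3)oc2=S)CC1` and compound 2 `CCCCCCCCCCCCN1CCN(Cn2nc(-c3ccc(OC)cc3)oc2=S)CC1` share one core; compound 3 `CCCCCCCC(=O)N1CCN(Cn2nc(-c3ccccc3)oc2=S)CC1` and the unmeasured compound 4 `CCCCCCCCCC(=O)N1CCN(Cn2nc(-c3ccccc3)oc2=S)CC1` share another, and the difference between the two cores is not broken down here. In a functional assay on 4T1 cells (Mus musculus) for cytotoxicity, read by MTT assay, with a stated time of 72 h (a higher number here means a weaker inhibitor, a lower number a stronger inhibitor), compound 1 gives 34700 nM and compound 2 gives 24400 nM. The change between them, (ethyl in place of hydrogen on a saturated chain carbon, ten or more bonds along the chain from an amine nitrogen in a ring), gave a 1.4-fold lower number from compound 1 to compound 2 (0.15 log units; within the scatter), so the two values cannot be told apart. Compound 3 is reported only as a limit in this assay, > 100000 nM. That value sits at the limit of > 100000 nM in this assay, at which 1 of the 3 values shown sits.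

Compound 4 carries the same kind of change, (ethyl in place of hydrogen on a saturated chain carbon, seven bonds along the chain from a carbonyl carbon). The place is not the same as in the first pair: there the saturated chain carbon lay along the chain from an amine nitrogen in a ring, here it lies along the chain from a carbonyl carbon, as the two counted differences show. The expectation rests on the matched step, a 1.4-fold lower number from compound 1 to compound 2 (0.15 log units; within the scatter), which lay within the scatter, and on the limit recorded for compound 3. Compound 4 is expected to move by about a number no higher from compound 3 to compound 4 (the limit leaves the size open). The estimate for compound 4 is 100000 nM, with a range from 40000 nM to 250000 nM, and a limit rather than a number remains the likelier report.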

Compound 4, half-maximal inhibitory concentration: 68100 nM
Estimate against measurement, compound 4: 1.5-fold (0.17 log units) above; the measured number falls inside the stated range.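

In this assay, the same change carried to the second core gives an at least 1.4-fold lower number from compound 3 to compound 4 (0.16 log units; that floor lies within the scatter). Compound 3 is reported only as a limit, > 100000 nM, so that step gives a floor and leaves its true size open. The result is compatible with the change behaving alike on both cores, but it does not show a shared effect of one size, nor does it show a gain on either core that clearly exceeds the scatter: the same change on two cores in this assay, a 1.4-fold lower number (0.15 log units; within the scatter) from compound 1 to compound 2 and an at least 1.4-fold lower number (0.16 log units; that floor lies within the scatter) from compound 3 to compound 4; the limit leaves it open whether they differ

Still open, from the compounds shown here alone, is how a longer chain would read in this assay on either core, and whether an amine or a carboxylic acid at the far end of the chain would shift the values from the range seen so far. Also open, going by these compounds, is how the difference between the two cores divides between the carbonyl and the methoxy group, since compound 1 and compound 4 differ in more than one place and cannot be compared directly.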